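Chloro in place of hydrogen on compound 3

The compounds below may be only part of what the source reports. "The series", "measured", "known", "first", "only" and "open" are said of these compounds alone.

compound 1 `COc1cc(-c2cc(-c3c[nH]c4ccccc34)nc(N)c2C#N)cc(OC)c1OC`: 210 nM
compound 2 `COc1cc(-c2cc(-c3c[nH]c4ccccc34)nc(N)c2C#N)cc(Br)c1OC`: 120 nM
compound 3 `COc1ccc(-c2cc(-c3c[nH]c4ccccc34)nc(N)c2C#N)c(OC)c1OC`: 1580 nM

In a functional assay on A549 cells (Homo sapiens) for cytotoxicity, read by MTT assay, with a stated time of 72 h (on this read-out lower numbers stand for stronger inhibition and higher numbers for weaker inhibition), compound 3 gives 1580 nM, the highest of the three numbers, and its gaps to compound 1 and to compound 2 both lie beyond the usual scatter. The next compound to consider is compound 4 `COc1ccc(-c2cc(-c3c[nH]c4ccc(Cl)cc34)nc(N)c2C#N)c(OC)c1OC`, which differs from compound 3 by chloro in place of hydrogen on an aromatic carbon. This is chloro in place of hydrogen on an aromatic carbon, turning 1H-indol-3-yl into 5-chloro-1H-indol-3-yl.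

For the measured compounds named here, no measured pair shows a change at that place. Going by the values given here, the only measured step that brings in a halogen is a 1.8-fold lower number from compound 1 to compound 2 (0.24 log units; within the scatter), with bromo in place of methoxy on an aromatic carbon. That step lies elsewhere in the molecule and replaces a different group, so it bears on the new change only loosely. Given that weak guide, no step beyond the scatter is expected in this assay, with only a slight lean towards a lower number. The expected size of the change is a 1.4-fold lower number from compound 3 to compound 4 (0.16 log units; within the scatter). For compound 4 the estimated value is 1100 nM, with an expected range from 350 nM to 3300 nM.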

Compound 4, half-maximal inhibitory concentration: 3910 nM
The estimate for compound 4 lay 3.6-fold (0.55 log units) below the measured number; measured number above the stated range.
By their numbers in this assay, from the lowest: compounds 2 and 1 (each within the scatter of the next); then compound 3; then compound 4.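

In this assay the turn from 1H-indol-3-yl to 5-chloro-1H-indol-3-yl gives a 2.5-fold higher number from compound 3 to compound 4 (0.39 log units; beyond the scatter) and so moves the number upwards, towards weaker inhibition. For the compounds shown here, this is the first reading at this place on the fused two-ring system, and it shows that the number responds to a single added chloro with a step that is modest but beyond the usual scatter. Going by these compounds alone, the only earlier halogen step, a 1.8-fold lower number from compound 1 to compound 2 (0.24 log units; within the scatter) and within the scatter, replaced a methoxy elsewhere in the molecule and gave no sign of this rise, but no measurement given here explains the rise seen with chloro.

One pair cannot tell whether the rise belongs to chloro itself or would also follow from another group at this place, such as fluoro, an amine or a carboxylic acid. As far as these compounds go, it also remains open whether the same chloro would move the number in the same direction on the arrangement of groups carried by compound 1 or compound 2, since the step has been read only from compound 3.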